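Meta substituent series on a shared core: hydroxy to hydrogen

The compounds below may be only part of what the source reports. "The series", "measured", "known", "first", "only" and "open" are said of these compounds alone.

Measured so far in an assay on HEK293 cells for displacement of a labelled ligand from Neuronal acetylcholine receptor; alpha3/beta4 (Homo sapiens), read by radioligand binding, with a stated time of 5 min; on this read-out higher numbers stand for weaker inhibition and lower numbers for stronger inhibition:
compound 1 `OCc1cccc(C2=NCCCC2)c1` gives 80 nM
compound 2 `Fc1cccc(C2=NCCCC2)c1` gives 108 nM
compound 3 `Oc1cccc(C2=NCCCC2)c1` gives 680 nM

Compound 3 stands at the highest number of the three. Its nearest neighbour is compound 2, and the step of a 6.3-fold higher number from compound 2 to compound 3 (0.80 log units; beyond the scatter) lies beyond the scatter. Against compound 1 the step of an 8.5-fold higher number from compound 1 to compound 3 (0.93 log units; beyond the scatter) is somewhat larger, also beyond the scatter. Compound 1 and compound 2 sit close together, with the step of a 1.4-fold higher number from compound 1 to compound 2 (0.13 log units; within the scatter) inside the scatter.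

Compound 4 `c1ccc(C2=NCCCC2)cc1` is not yet measured. The change from compound 3 is hydrogen in place of hydroxy on an aromatic carbon, leaving the shared core with no substituent at that position.

Going by the values given here, no measured step removes the hydroxy altogether, so the comparison is indirect. Both steps that lead into compound 3, an 8.5-fold higher number from compound 1 to compound 3 (0.93 log units; beyond the scatter) and a 6.3-fold higher number from compound 2 to compound 3 (0.80 log units; beyond the scatter), show that the hydroxy gives a clearly higher number than the two other groups tried at this carbon. Removing it is therefore expected to give a lower number than compound 3, plausibly back toward the range of compound 1 and compound 2, though the unsubstituted case could also fall between.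

Compound 4 is estimated at 160 nM, range 50 nM to 500 nM, a step of a 4.3-fold lower number from compound 3 to compound 4 (0.63 log units; beyond the scatter) expected downward from compound 3.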

Compound 4, inhibition constant: 194 nM
Beside the measured number, compound 4's estimate is 1.2-fold (0.08 log units) below it; the measured number falls inside the stated range.
By their numbers in this assay, from the lowest: compounds 1, 2 and 4 (each within the scatter of the next, the first and the last beyond it); then compound 3.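

In this assay, going by these compounds alone, compound 4 gives the first direct reading of this aromatic carbon with hydrogen in place of a substituent, and the hydroxy stands clearly apart from it (a 3.5-fold lower number from compound 3 to compound 4 (0.54 log units; beyond the scatter)), so the high number of compound 3 is not a feature of the shared core alone. Fluoro cannot be told apart from hydrogen (a 1.8-fold higher number from compound 2 to compound 4 (0.25 log units; within the scatter)), whereas hydroxymethyl reads apart from hydrogen on the side of the lower number, though only modestly (a 2.4-fold higher number from compound 1 to compound 4 (0.38 log units; beyond the scatter)). Substitution at this carbon therefore has no single direction against hydrogen among the groups shown: compound 3 carries a higher number than compound 4, compound 1 a lower one, and compound 2 shows no readable difference.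

No evidence at hand accounts for hydroxy and hydroxymethyl falling on opposite sides of hydrogen. Still open, going by these compounds, is how methoxy, an amine or a hydroxyethyl chain at this carbon would read against hydrogen and hydroxymethyl, and whether these groups would keep the same order on other carbons of the aromatic ring.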